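From 4-methylphenyl to hexyl on the shared core

This account rests on a few compounds, and the source may have more. Where it says the series, first, only, none or still open, it means among the compounds named here.

- Compound 1 `Cc1ccc(-c2cn(CCCN3C(=O)COc4ccccc43)nn2)cc1`: 14300 nM
- Compound 2 `CCCCCc1ccc(-c2cn(CCCN3C(=O)COc4ccccc43)nn2)cc1`: > 100000 nM, a limit
- Compound 3 `COc1ccc2cc(-c3cn(CCCN4C(=O)COc5ccccc54)nn3)ccc2c1`: > 100000 nM, a limit

Going by the values given here, in a functional assay on HeLa cells (Homo sapiens) for antiproliferative activity, read by sulforhodamine B assay, with a stated time of 48 h (on this read-out lower numbers stand for stronger inhibition of growth and higher numbers for weaker inhibition of growth), compound 1 gives 14300 nM, the only true number so far. The rest of the series sits at the limit of > 100000 nM in this assay, at which 2 of the 3 values shown sit.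

Compound 4 `CCCCCCc1cn(CCCN2C(=O)COc3ccccc32)nn1` is still unmeasured. It differs from compound 1 by hexyl in place of 4-methylphenyl on an aromatic carbon, which is hexyl in place of 4-methylphenyl on an aromatic carbon.

Among the compounds with values here, only one measured step offers guidance: an at least 6.9-fold higher number from compound 1 to compound 2 (0.84 log units; beyond the scatter). That change puts butyl in place of hydrogen on a saturated chain carbon bound to an aromatic carbon. Within the data shown here, it is only a loose guide, since compound 2 keeps the aromatic ring that compound 4 gives up, and no measured step removes that ring. Even so, a modest move to a higher number in this assay seems the likeliest outcome, and a limit is possible.

The estimated change is a 2.8-fold higher number from compound 1 to compound 4 (0.45 log units; beyond the scatter). For compound 4 the expected value is 40000 nM, with an estimated range from 12000 nM to 100000 nM.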

Compound 4, concentration for 50% growth inhibition: 100 nM
Beside the measured number, compound 4's estimate is 400-fold (2.60 log units) above it; the whole stated range lies above it.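

In this assay, the group on this aromatic carbon can push the number strongly downward, not only upward: hexyl in place of 4-methylphenyl gives a 140-fold lower number from compound 1 to compound 4 (2.16 log units; beyond the scatter). Going by these compounds alone, the only earlier step, an at least 6.9-fold higher number from compound 1 to compound 2 (0.84 log units; beyond the scatter), ran the other way, so this is the first sign that a compound without the six-membered aromatic ring at this place can inhibit growth strongly. Compound 2 and compound 3 each remain at a limit of the assay, not a true number: the limit of > 100000 nM in this assay, at which 2 of the 4 values shown sit.

On these data alone, whether the gain comes from the hexyl chain itself or from the loss of the aromatic ring stays open. An octyl chain, a cyclohexyl ring or a hexyl chain ending in an amine at this place would help separate those two readings.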